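Lengthening the chain from compound 3 to compound 4

The source may hold more compounds than are shown below. What is called first, only, known or untested is meant among the compounds shown, and "the series" means these compounds.

In a functional assay on RAW264.7 cells (Mus musculus) for inhibition, read by ELISA, with a stated time of 24 h (a higher number here means that more compound is needed for the effect, a lower number that less compound is needed), compound 1 (`CC/C=C\C[C@H]1C(=O)C=C[C@H]1CC(=O)OCC`) reads 20000 nM while compound 2 (`CC/C=C\C[C@H]1C(=O)C=C[C@H]1CC(=O)OCCCCC`) reads 25000 nM and compound 3 (`CC/C=C\C[C@H]1C(=O)C=C[C@H]1CC(=O)OCCO`) reads 24000 nM and stands within the scatter of both. Compound 4 (`CC/C=C\C[C@H]1C(=O)C=C[C@H]1CC(=O)OCCOCCOCCO`) differs from compound 3 by 2-(2-hydroxyethoxy)ethyl in place of hydrogen on an oxygen on a saturated carbon in one change: 2-(2-hydroxyethoxy)ethyl in place of hydrogen on an oxygen on a saturated carbon. The measured steps that bear on it are (a 1.3-fold higher number from compound 1 to compound 2 (0.10 log units; within the scatter)) and (a 1.2-fold higher number from compound 1 to compound 3 (0.08 log units; within the scatter)) and (a 1.0-fold lower number from compound 2 to compound 3 (0.02 log units; within the scatter)), all on a saturated chain carbon and all within the scatter. Among the measured compounds shown here, no measured compound carries the entering group. In this assay no step beyond the scatter is expected. The expected step is a 1.0-fold higher number from compound 3 to compound 4 (0.02 log units; within the scatter) on this reading. Compound 4 is estimated at 25000 nM with an expected range from 12000 nM to 50000 nM around it.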

Compound 4, half-maximal effective concentration: 42000 nM
Beside the measured number, compound 4's estimate is 1.7-fold (0.23 log units) below it, within the range that was stated.
By their numbers in this assay, from the lowest: compounds 1, 3, 2 and 4 (each within the scatter of the next, the first and the last beyond it).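

Placing 2-(2-hydroxyethoxy)ethyl on the oxygen gives a 1.8-fold higher number from compound 3 to compound 4 (0.24 log units; within the scatter) in this assay and, with 2-(2-hydroxyethoxy)ethoxy in place of propyl, a 1.7-fold higher number from compound 2 to compound 4 (0.23 log units; within the scatter) as the neighbouring step. Among the compounds shown here, the first step at this position to pass the scatter is a 2.1-fold higher number from compound 1 to compound 4 (0.32 log units; beyond the scatter) and it holds only against the ethyl ester, while both steps above stay inside it. Nothing available accounts for this step. Open, on these data alone, is how an amine or a carboxylic acid in place of 2-(2-hydroxyethoxy)ethoxy would read, and whether a longer chain would widen the step.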